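Methoxy removal on the diarylpropane series, cytotoxicity check

The source may report more compounds than this note shows. Statements on the series, on what has been measured and on what is new or still open speak of the compounds shown alone.

Three compounds have been run in an ADME assay on RAW264.7 cells (Mus musculus) for cytotoxicity, read by MTT assay, with a stated time of 24 h, tested at 1.25 ug/mL; on this read-out higher numbers stand for a weaker effect at the one concentration tested and lower numbers for a stronger effect. Compound 1 `COc1ccc(CCCc2ccc(OC)c(OC)c2)c(O)c1` and compound 2 `COc1ccc(CCC(=O)c2cccc(O)c2)cc1` are diarylpropane-type structures with one free hydroxyl each, and compound 3 `COc1ccc(CCCc2ccc(OC)cc2OC)c(O)c1` carries three methoxy groups with one hydroxyl. In this assay compound 3 gives 100%, while compound 1 gives 97.9% and compound 2 gives 97.5%. All three numbers lie within the scatter of one another, so none of the compounds separates itself at the concentration tested and all sit near the no-effect end of the read-out.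

Compound 4 `COc1ccc(CCCc2ccc(OC)cc2O)cc1` has not been measured. Relative to compound 3 the change is hydrogen in place of methoxy on an aromatic carbon. Within the data shown here, no step between measured compounds that differ in a single place is available, so the effect of this change has to be judged from the flat picture across compounds 1, 2 and 3 alone.

With every measured number close together and near full activity, the step from compound 3 to compound 4 is expected to be a number 2 percentage points lower from compound 3 to compound 4 (within the scatter), that is, no change beyond the scatter in either direction. Compound 4 is therefore estimated at 98%, with a range from 90% to 103%.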

Compound 4, a percentage reported as activity, at one concentration (the size of the read-out at that concentration, not a potency): 98.9%
The estimate for compound 4 lay 0.9 percentage points below the measured number, and the stated range covers the measured number.
By their numbers in this assay, from the lowest: compounds 2, 1, 4 and 3 (each within the scatter of the next).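

In this assay, among these compounds, hydrogen in place of methoxy on an aromatic carbon, ortho to a large group and meta to a methoxy group, gives a number 1.1 percentage points lower from compound 3 to compound 4 (within the scatter), the first single-place reading for the series, so the methoxy at this position can go without a change beyond the scatter at the one concentration tested. The same kind of exchange read against the other trimethoxy-free comparison in the set gives a number 1 percentage points higher from compound 1 to compound 4 (within the scatter), so both single-place steps now available agree with the flat picture rather than merely inferring it from unrelated structures. No supporting measurement bears on this result, and the series offers no explanation for it.

Going by these compounds, whether a different group on this aromatic carbon, such as an amine or a carboxylic acid, would move the read-out beyond the scatter stays open. Also open, on these data alone, is whether the exchange of methoxy for hydrogen would stay this silent at any concentration other than the single one reported, since a read-out near the no-effect end can hide differences between these compounds.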